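The compounds below may be only part of what the source reports. "The series", "measured", "known", "first", "only" and "open" are said of these compounds alone.

The measured compounds, all tested in a functional assay on QGY7701 cells (Homo sapiens) for cytotoxicity, read by MTT assay, with a stated time of 24 h; a lower number here means a stronger inhibitor, a higher number a weaker inhibitor:

Compound 1, `C=CC1=C(C(=O)NCCCCC)C(c2ccc(Cl)c(Cl)c2)OC1`, reaches only the limit of the measurement, giving > 100000 nM.
Compound 2, `C=CC1=C(C(=O)NCc2ccccc2F)C(c2ccc(F)cc2)OC1`, gives 51400 nM.
Compound 3, `C=CC1=C(C(=O)Nc2ccccc2)C(c2ccc(OC)cc2)OC1`, also stops at the limit of the measurement, giving > 100000 nM.

Among the measured compounds shown here, compound 2 is therefore the one compound of the three with an actual number; the other two sit at the upper limit of what this assay can report, which is the limit of > 100000 nM in this assay, at which 2 of the 3 values shown sit. For the measured compounds named here, no two measured compounds differ in just one place, so no measured step can be set beside the change that is to come.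

Compound 4, `C=CC1=C(C(=O)NC2CCCCC2)C(c2ccc(F)cc2)OC1`, differs from compound 2 by a single exchange: cyclohexyl in place of 2-fluorobenzyl on an amide-type nitrogen. Going by the values given here, with no measured step to lean on, the expectation rests on where compound 2 stands and on the two limits around it. A step toward a weaker inhibitor is expected for compound 4, on the order of a 1.9-fold higher number from compound 2 to compound 4 (0.29 log units; within the scatter). Compound 4 is thus expected to give about 100000 nM, within a range from 45000 nM to 250000 nM, with a fair chance that only a limit is reported.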

Compound 4, half-maximal inhibitory concentration: 40500 nM
Compound 4: middle estimate off by 2.5-fold (0.39 log units), on the high side; measured number below the stated range.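

In this assay, among the compounds shown here, putting cyclohexyl in place of 2-fluorobenzyl on an amide-type nitrogen gives a 1.3-fold lower number from compound 2 to compound 4 (0.10 log units; within the scatter), the first change in a single place that can be read. For this one pair, an aromatic ring can give way to a non-aromatic ring with fewer heavy atoms without a change in the number beyond the usual scatter of the measurement. Compound 1 and compound 3 differ from these two in more than one place and remain at a limit rather than a number: the limit of > 100000 nM in this assay, at which 2 of the 4 values shown sit.

Still open, on these data alone, is whether an amine, a carboxylic acid or a longer chain on that nitrogen would move the number beyond the scatter. A single pair also cannot show whether the same exchange would behave alike on a different core.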